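Swapping bromo for nitro on a diaryl ether

The compounds below may be only part of what the source reports. "The series", "measured", "known", "first", "only" and "open" are said of these compounds alone.

Measured so far:
Compound 1, `O=c1c2ccccc2nc(-c2ccccc2)n1/N=C/c1ccc(Oc2ccc(Br)cc2)cc1`, gives 6.39 in a physicochemical assay for lipophilicity, in phosphate buffer, measured as octanol-water partition; on this read-out lower numbers stand for lower lipophilicity and higher numbers for higher lipophilicity.
Compound 2, `CCCc1nc2ccccc2c(=O)n1/N=C/c1ccc(Oc2ccc(F)cc2)cc1`, gives 5.22 in this assay.

Compound 1 stands highest of the two numbers; compound 2, the nearest, lies lower by a gap beyond the scatter. For the measured compounds named here, the two compounds differ in more than one place, so no single step between them is laid out, and their two values can only be set side by side.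

Compound 3, `O=c1c2ccccc2nc(-c2ccccc2)n1/N=C/c1ccc(Oc2ccc([N+](=O)[O-])cc2)cc1`, is not yet measured. It differs from compound 1 by one change: nitro in place of bromo on an aromatic carbon. Going by the values given here, no measured pair shows this kind of change, so the expectation rests on what is counted in it. The group that leaves carries no hydrogen-bond acceptors, the group that enters carries two. A downward step of moderate size is expected, a number 1.09 log units lower from compound 1 to compound 3 (beyond the scatter). Compound 3 is estimated at 5.3, with a range from 4.7 to 5.9.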

Compound 3, partition coefficient: 6.12
Compound 3: middle estimate off by 0.82 log units, on the low side, outside the stated range (above it).
By their numbers in this assay, from the lowest: compound 2; then compounds 3 and 1 (each within the scatter of the next).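

In this assay, for the compounds shown here, this single change gives a number 0.27 log units lower from compound 1 to compound 3 (within the scatter), so the direct comparison that the earlier compounds could not offer finds no real difference between compound 1 and compound 3. On the core of compound 1, at this aromatic carbon para to a large group, nitro with its two hydrogen-bond acceptors and bromo with none read alike, so in this one pair the acceptor count does not follow the read-out. Nothing measured here explains why the two groups read alike.

This single pair leaves open whether nitro and bromo would also read alike on the core of compound 2, which carries a propyl chain in place of the phenyl group. It also leaves open how an amine or a carboxylic acid at this same aromatic carbon would read in this assay on the core of compound 1.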